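Vinyl ester versus thiophene ester: cytotoxicity on Vero cells

A few compounds are considered here, and "the series" means these few. Any claim that something is new, unique, unknown or untested is made for them only; others in the source may bear on it.

Compound 1, `CCCC(=O)OC1CCC(CN2CCN(c3cc(=O)c4cc(C(F)(F)F)cc([N+](=O)[O-])c4s3)CC2)CC1`, in an ADME assay on Vero cells (Chlorocebus sabaeus) for cytotoxicity, read by MTT assay, with a stated time of 48 h (on this read-out higher numbers stand for weaker inhibition and lower numbers for stronger inhibition), gives > 64 ug/mL, which is a limit of the assay and not a number.
Compound 2, `O=C(OC1CCC(CN2CCN(c3cc(=O)c4cc(C(F)(F)F)cc([N+](=O)[O-])c4s3)CC2)CC1)c1ccc(F)cc1`, in this assay gives > 64 ug/mL, again a limit.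
Compound 3, `O=C(OC1CCC(CN2CCN(c3cc(=O)c4cc(C(F)(F)F)cc([N+](=O)[O-])c4s3)CC2)CC1)c1cccs1`, in this assay gives > 64 ug/mL, also a limit.

Compound 3 therefore stands at a limit, and so do both other compounds (the limit of > 64 ug/mL in this assay, at which 3 of the 3 values shown sit). The steps among them, a step that the two limits leave unreadable from compound 1 to compound 2, a step that the two limits leave unreadable from compound 1 to compound 3 and a step that the two limits leave unreadable from compound 2 to compound 3, cannot be sized because both ends of each are limits.

Compound 4, `C=CC(=O)OC1CCC(CN2CCN(c3cc(=O)c4cc(C(F)(F)F)cc([N+](=O)[O-])c4s3)CC2)CC1`, has not been measured. It differs from compound 3 in one place: vinyl in place of thiophen-2-yl on a carbonyl carbon. This is a swap of the group on a carbonyl carbon whose other neighbour is the oxygen of the ester.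

Among the measured compounds shown here, no measured step bears on this swap, since each of the measured pairs compares groups that are all at the limit. The three limits only show that changing the ester group has so far not brought the value into the readable range. The expected step that the limit leaves unreadable from compound 3 to compound 4 is therefore not readable from what is known, and the most likely outcome for compound 4 in this assay is estimated as 70 ug/mL, with a range from 15 ug/mL to 250 ug/mL.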

Compound 4, half-maximal inhibitory concentration: > 64 ug/mL
Compound 4: only a limit was reported; the forecaster's own chance of this, stated with the estimate: 65%; the middle value lies beyond the limit too.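

Compound 4, like compound 1, compound 2 and compound 3, gives only a limit and not a number in this assay, so no step among these four compounds can be read: the limit of > 64 ug/mL in this assay, at which 4 of the 4 values shown sit.

The compounds shown leave open whether propyl, 4-fluorophenyl, thiophen-2-yl and vinyl differ at all in this assay, and what change would bring a value into the readable range.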